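A few compounds are considered here, and "the series" means these few. Any claim that something is new, unique, unknown or untested is made for them only; others in the source may bear on it.

Of the compounds shown here, two sharing one core have numbers so far in a physicochemical assay for solubility, measured as kinetic solubility, at pH 7.4; a higher number here means a more soluble compound, a lower number a less soluble compound. Compound 1 `COc1cc(N2CCN(CC3CCOC3)CC2)ccc1Nc1nc(NC2CCCCC2)c2nc[nH]c2n1` gives 5000 nM, and compound 2 `COc1cc(N2CCC(CC(=O)N3CCOCC3)CC2)ccc1Nc1nc(NC2CCCCC2)c2nc[nH]c2n1` gives 19000 nM. Compound 2 therefore stands highest of the two, with a gap to compound 1 that lies beyond the scatter. The two compounds differ in more than one place, so their gap does not isolate a single structural change.

The next compound is compound 3 `CCN(CC)CC1CCN(c2ccc(Nc3nc(NC4CCCCC4)c4nc[nH]c4n3)c(OC)c2)CC1`, which keeps the core of compound 2 and changes only the side chain: diethylamino in place of (morpholin-4-yl)carbonyl on a saturated chain carbon bound to a saturated ring carbon. Among the compounds with values here, no measured pair tests this replacement, and neither measured compound carries the diethylamino group. The expectation therefore starts from compound 2 at 19000 nM, with no firm basis for favouring a direction in this assay. The estimated step of a 1.2-fold higher number from compound 2 to compound 3 (0.06 log units; within the scatter) is expected to stay within the scatter. Within the data shown here, the span from compound 1 at 5000 nM to compound 2 at 19000 nM is the only guide to how far this side chain position can move the number, so the range is kept wide. For compound 3 the expected value is 22000 nM, with an estimated range of 7000 nM to 60000 nM.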

Compound 3, solubility: 19000 nM
Beside the measured number, compound 3's estimate is 1.2-fold (0.06 log units) above it; the measured number falls inside the stated range.
By their numbers in this assay, from the lowest: compound 1; then compounds 2 and 3 (each within the scatter of the next).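

In this assay, diethylamino in place of (morpholin-4-yl)carbonyl on a saturated chain carbon bound to a saturated ring carbon gives no change at the digits printed from compound 2 to compound 3 (within the scatter), so at this position the number holds with the six-membered non-aromatic ring and the double bond outside aromatic rings both gone. Within the data shown here, the wider replacement on an aromatic carbon, 4-((diethylamino)methyl)piperidin-1-yl in place of 4-((oxolan-3-yl)methyl)piperazin-1-yl, gives a 3.8-fold higher number from compound 1 to compound 3 (0.58 log units; beyond the scatter), a modest step and the first single-place comparison that lies beyond the scatter. No measurement available here accounts for either step.

The step from compound 1 to compound 3 replaces the whole group on the aromatic carbon, so the compounds shown do not separate the piperidine from the piperazine, or the diethylamino from the oxolan-3-yl end of that group. As far as these compounds go, it also remains open whether a carboxylic acid, a primary amine or a longer chain on the saturated chain carbon would stay within the scatter of compound 2 and compound 3, or move away from them.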